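Isopropyl for methyl on the carbonyl of compound 2

A few compounds are considered here, and "the series" means these few. Any claim that something is new, unique, unknown or untested is made for them only; others in the source may bear on it.

In a functional assay on MCF7 cells (Homo sapiens) for antiproliferative activity, read by MTT assay, with a stated time of 48 h (a higher number here means a weaker inhibitor, a lower number a stronger inhibitor), compound 1 (`CC(C)=CCC[C@](C)(/C=C/[C@@H](OC(=O)C=C(C)C)[C@](C)(O)/C=C/C(=O)/C=C/N(C)C)CC=O`) reads 12200 nM and compound 2 (`CC(=O)O[C@@H]1/C=C/[C@@](C)(CCC=C(C)C)C/C=C(/CO)C(=O)/C=C/[C@@]1(C)O`) reads 7890 nM with the two values within the scatter of each other, so compound 2 cannot be ranked against compound 1.

Compound 3 (`CC(C)=CCC[C@]1(C)/C=C/[C@@H](OC(=O)C(C)C)[C@](C)(O)/C=C/C(=O)/C(CO)=C\C1`) is not yet measured. It differs from compound 2 by isopropyl in place of methyl on a carbonyl carbon with isopropyl in place of methyl on a carbonyl carbon, so that acetoxy becomes (isopropylcarbonyl)oxy.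

Among the measured compounds shown here, no measured pair differing in one place gives a size for this change. In this assay a step no larger than the scatter is therefore expected, with no firm direction. For the measured compounds named here, the starting point is compound 2 at 7890 nM as the only reference for this change. The estimated value for compound 3 is 7000 nM with an expected range of 3000 nM to 16000 nM in this series. The expected shift is a 1.1-fold lower number from compound 2 to compound 3 (0.05 log units; within the scatter) and remains within the scatter.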

Compound 3, half-maximal inhibitory concentration: 11700 nM
Beside the measured number, compound 3's estimate is 1.7-fold (0.22 log units) below it; measured number inside the range.
By their numbers in this assay, from the lowest: compounds 2, 3 and 1 (each within the scatter of the next).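

In this assay the step of a 1.5-fold higher number from compound 2 to compound 3 (0.17 log units; within the scatter) gives the first size for isopropyl in place of methyl on a carbonyl carbon. Acetoxy and (isopropylcarbonyl)oxy therefore cannot be told apart at this position, and compound 2 and compound 3 stay unranked. Nothing at hand bears on why the two read alike.

From the compounds shown here alone, whether any group on this carbonyl carbon can move the number beyond the scatter remains open; a longer chain, a phenyl ring or an amine in place of isopropyl would test this. Going by these compounds, with a single step at this position, it also remains open whether the same change would read the same way on a different core, such as that of compound 1.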